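Methoxymethyl in place of trifluoromethyl at the aromatic ring

A few compounds are considered here, and "the series" means these few. Any claim that something is new, unique, unknown or untested is made for them only; others in the source may bear on it.

Measured compounds: compound 1 `CCCc1cccc(C[C@H](O)/C=C/[C@H]2CSC(=O)N2CCSCCCC(=O)O)c1`, 1200 nM; compound 2 `CCc1cccc(C[C@H](O)/C=C/[C@H]2CSC(=O)N2CCSCCCC(=O)O)c1`, 65 nM; compound 3 `O=C(O)CCCSCCN1C(=O)SC[C@@H]1/C=C/[C@@H](O)Cc1cccc(C(F)(F)F)c1`, 280 nM, all in an assay on CHO cells for displacement of a labelled ligand from prostaglandin E2 receptor EP3 subtype (Mus musculus), read by scintillation counting, with a stated time of 60 min; on this read-out higher numbers stand for weaker inhibition and lower numbers for stronger inhibition.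

Compound 3 stands second highest of the three numbers, with a 4.3-fold lower number from compound 1 to compound 3 (0.63 log units; beyond the scatter) and a 4.3-fold higher number from compound 2 to compound 3 (0.63 log units; beyond the scatter). Compound 4 `COCc1cccc(C[C@H](O)/C=C/[C@H]2CSC(=O)N2CCSCCCC(=O)O)c1` differs from compound 3 by methoxymethyl in place of trifluoromethyl on an aromatic carbon. Going by the values given here, no measured step covers methoxymethyl; the nearest guides are the two modest steps above, which show that exchanges of the group on this aromatic carbon shift the number only modestly, whereas an 18-fold lower number from compound 1 to compound 2 (1.27 log units; beyond the scatter) shows a large shift is possible. For compound 4 the estimate is a step within or near the scatter, a 1.4-fold lower number from compound 3 to compound 4 (0.15 log units; within the scatter). Compound 4 is therefore expected at 200 nM, ranging from 50 nM to 800 nM.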

Compound 4, inhibition constant: > 10000 nM
Compound 4 gave a limit, no number; the forecaster's own chance of this, stated with the estimate: 5%; middle value at least 50-fold (1.69 log units) away from the limit.
By their numbers in this assay, from the lowest: compound 2; then compound 3; then compound 1. At a limit, above all of these: compound 4.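

In this assay, compound 4 stands at a limit of the assay, not at a number: the limit of > 10000 nM in this assay, at which 1 of the 4 values shown sits.

Methoxymethyl on this aromatic carbon thus gives an at least 35-fold higher number from compound 3 to compound 4 (1.55 log units; beyond the scatter), along with an at least 150-fold higher number from compound 2 to compound 4 (2.18 log units; beyond the scatter) and an at least 8.3-fold higher number from compound 1 to compound 4 (0.92 log units; beyond the scatter). Ethyl, propyl and trifluoromethyl all gave numbers here, whereas methoxymethyl shows that a single change at this position can take the compound to the limit.

The compounds shown leave open whether the chain oxygen is what matters, as neither a hydroxymethyl nor an ethoxymethyl group appears among them. On these data alone, the full size of these steps also stays open, since compound 4 has only a limit.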